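The compounds below may be only part of what the source reports. "The series", "measured", "known", "first", "only" and "open" are said of these compounds alone.

Compound 1 `C=CCn1c(=O)/c(=C\c2cccc(F)c2)[nH]c(=O)/c1=C\c1ccccc1OC` belongs to a small set of closely related compounds tested in a functional assay on HL-60 cells (Homo sapiens) for cytotoxicity, read by CCK-8 assay, with a stated time of 72 h; on this read-out higher numbers stand for weaker inhibition and lower numbers for stronger inhibition. In this assay compound 1 gives 8890 nM. Compound 3 `C=CCn1c(=O)/c(=C\c2cccc(Br)c2)[nH]c(=O)/c1=C\c1ccccc1OC` carries bromo in place of fluoro on an aromatic carbon, and in this assay compound 3 gives 5200 nM; the step of a 1.7-fold lower number from compound 1 to compound 3 (0.23 log units; within the scatter) stays within the scatter. Compound 2 `C=CCn1c(=O)/c(=C\c2ccc(F)c(Br)c2)[nH]c(=O)/c1=C\c1ccccc1OC` was reported in this assay as "not active" (no number reported), with no number given. Compound 1 thus stands at the upper end of the two recorded numbers, by a margin that is within the scatter.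

Compound 4 `C=CCn1c(=O)/c(=C\c2ccc(C)cc2)[nH]c(=O)/c1=C\c1ccccc1OC` differs from compound 1 in a single place: 4-methylphenyl in place of 3-fluorophenyl on a double-bonded chain carbon bound to an aromatic carbon. Going by the values given here, no measured step exchanges one of these two rings for the other, so the only guidance is indirect. The step of a 1.7-fold lower number from compound 1 to compound 3 (0.23 log units; within the scatter) shows that swapping one substituent on that ring for another left the number within the scatter, while compound 2 shows that a compound of this series can also fail to give any number at all. On this basis compound 4 is expected to change little, the estimated step being a 1.0-fold higher number from compound 1 to compound 4 (0.01 log units; within the scatter). In this assay compound 4 is estimated at 9000 nM, with a range from 3000 nM to 30000 nM.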

Compound 4, half-maximal inhibitory concentration: "not active" (no number reported)
Nothing numeric was reported for compound 4; there is nothing to compare the estimate with.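

Going by these compounds alone, compound 4 was reported in this assay as not active, with no number given, so no step from compound 1 to compound 4 can be read. No measurement shown explains this result. The compounds shown leave open how far compound 4 lies from compound 1 in this assay, and which ring substituents allow a number at all.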